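This account rests on a few compounds, and the source may have more. Where it says the series, first, only, none or still open, it means among the compounds named here.

Compound 1 `CC(=O)SCC(=O)c1ccc(NS(=O)(=O)c2ccccc2Cl)cc1`: "not determined" (no result reported)
Compound 2 `CC(=O)SCC(=O)c1ccc(NS(=O)(=O)c2cccc(Cl)c2)cc1`: "not determined" (no result reported)
Compound 3 `CC(=O)SCC(=O)c1ccc(NS(=O)(=O)c2ccc(C)cc2)cc1`: 6500 nM

For the measured compounds named here, in a functional assay on HCT-116 cells (Homo sapiens) for cytotoxicity (a lower number here means that less compound is needed, a higher number that more compound is needed for the effect), compound 3 gives 6500 nM, the only number in this small set, since neither of the other two compounds has a reported result. Compound 4 `COc1cccc(S(=O)(=O)Nc2ccc(C(=O)CSC(C)=O)cc2)c1` has not yet been measured. It carries 3-methoxyphenyl in place of 4-methylphenyl on a sulfonyl sulfur. Going by the values given here, no measured pair shows what such a change does in this assay, so no step beyond the scatter is expected, and no direction is predicted. The estimated step is a 1.1-fold lower number from compound 3 to compound 4 (0.03 log units; within the scatter). For compound 4 the estimated value is 6000 nM, with an expected range from 2000 nM to 20000 nM.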

Compound 4, half-maximal effective concentration: 2600 nM
Compound 4: the middle estimate sits 2.3-fold (0.36 log units) above what was measured, and the stated range covers the measured number.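

In this assay, for the compounds shown here, replacing 4-methylphenyl with 3-methoxyphenyl on a sulfonyl sulfur gives a 2.5-fold lower number from compound 3 to compound 4 (0.40 log units; beyond the scatter), the first readable step in this set, showing that this place responds to a change of its group. The entering group differs both in its substituent and in that substituent's ring position, so this single step cannot separate the two changes. Nothing available here explains the step.

Steps involving compound 1 and compound 2 cannot be read. From the compounds shown here alone, it remains open how 3-methylphenyl, 4-methoxyphenyl or a ring bearing a carboxylic acid or an amine would behave at this place.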